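Bromine position on the benzyl arm of the core

This account rests on a few compounds, and the source may have more. Where it says the series, first, only, none or still open, it means among the compounds named here.

Two members of the series have numbers. Compound 1 `CCN(Cc1cccc(Br)c1)c1cccc(C(=O)N2CCc3ccc(OS(N)(=O)=O)cc3C2)c1` in an assay on HEK293 cells for inhibition of Steryl-sulfatase (Homo sapiens), tested at 0.1 uM (on this read-out higher numbers stand for a stronger effect at the one concentration tested and lower numbers for a weaker effect), gives 20.9%. Compound 2 `CN(C)CCN(Cc1ccccc1)c1ccc(C(=O)N2CCc3ccc(OS(N)(=O)=O)cc3C2)cc1` in this assay gives 13.9%, and the two numbers lie within the scatter of each other, so nothing separates them. Compound 3 `CCN(Cc1ccc(Br)cc1)c1cccc(C(=O)N2CCc3ccc(OS(N)(=O)=O)cc3C2)c1` is not yet measured; it differs from compound 1 in one place: 4-bromophenyl in place of 3-bromophenyl on a saturated chain carbon bound to a nitrogen on an aromatic ring. Among the measured compounds shown here, no measured pair shows this change, so the expected step in this assay is set at none beyond the scatter, with no direction, as a number 0.9 percentage points lower from compound 1 to compound 3 (within the scatter). Compound 3 is accordingly expected to give 20%, in the range 8% to 35%.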

Compound 3, a percentage reported as inhibition, at one concentration (the size of the read-out at that concentration, not a potency): 24.2%
The estimate for compound 3 lay 4.2 percentage points below the measured number; low and high end bracket the measured number.
By their numbers in this assay, from the lowest: compounds 2, 1 and 3 (each within the scatter of the next, the first and the last beyond it).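

Swapping 3-bromophenyl for 4-bromophenyl on a saturated chain carbon bound to a nitrogen on an aromatic ring gives a number 3.3 percentage points higher from compound 1 to compound 3 (within the scatter) in this assay. This first measured pair at this position therefore does not separate the two bromophenyl isomers at the one concentration tested. No available measurement offers a reason for the step. Still open, on these data alone, is whether the bromine is needed on this arm at all. Also open, as far as these compounds go, is how a carboxylic acid in its place, or a longer chain in place of the ethyl on the nitrogen, would read.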